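From compound 2 to compound 4: working notes

This account rests on a few compounds, and the source may have more. Where it says the series, first, only, none or still open, it means among the compounds named here.

Measured in a functional assay on SGC-7901 cells (Homo sapiens) for antiproliferative activity, read by MTT assay, with a stated time of 24 h (a higher number here means a weaker inhibitor, a lower number a stronger inhibitor), so far:
- compound 1 `Cc1cccc(NNC(=O)c2cccc(NS(=O)(=O)c3cnc(O)nc3O)c2)c1` gives > 20000 nM as a limit
- compound 2 `O=C(NNc1ccccc1F)c1ccccc1NS(=O)(=O)c1cnc(O)nc1O` gives > 20000 nM as a limit
- compound 3 `O=C(NNC(=O)c1ccccc1F)c1ccc(NS(=O)(=O)c2cnc(O)nc2O)cc1` gives > 20000 nM as a limit

Compound 2 stands at > 20000 nM as a limit of the assay and not a number. Going by the values given here, the other two compounds give limits as well, so the series so far shows only the limit of > 20000 nM in this assay, at which 3 of the 3 values shown sit, and no measured number.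

Compound 4 `O=C(NNC(=O)c1ccccc1NS(=O)(=O)c1cnc(O)nc1O)c1ccccc1Cl` has not yet been measured. The change to it is (2-chlorophenyl)carbonyl in place of 2-fluorophenyl on an amine nitrogen and puts (2-chlorophenyl)carbonyl in place of 2-fluorophenyl on an amine nitrogen.

In this assay the expected step of a number no higher from compound 2 to compound 4 (the limit leaves the size open) is none beyond the scatter, and a further limit is the most likely report. That expectation rests on compound 2 with > 20000 nM as a limit. If a number is reported, the estimate for compound 4 is 20000 nM with an expected range from 6000 nM to 40000 nM for this measurement.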

Compound 4, half-maximal inhibitory concentration: 2410 nM
Compound 4: the middle estimate sits 8.3-fold (0.92 log units) above what was measured, and the stated range ends above it.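

In this assay, (2-chlorophenyl)carbonyl in place of 2-fluorophenyl on an amine nitrogen gives an at least 8.2-fold lower number from compound 2 to compound 4 (0.91 log units; beyond the scatter), so this position can carry a change that moves the read-out beyond the scatter. Going by these compounds alone, compound 4 is the first compound to return a number and not a limit. Only a lower bound can be placed on the size of the step, as its starting point is a limit of the assay: the limit of > 20000 nM in this assay, at which 3 of the 4 values shown sit.

The step joins two differences, the added carbonyl and chlorine for fluorine, and the compounds shown do not separate them. Going by these compounds, whether the number in this assay depends on the aromatic ring at all, or whether a small acetyl group on the same nitrogen would also give a number, remains open.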